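Thiazole to pyrazole amide: solubility expected to recover

The compounds below may be only part of what the source reports. "The series", "measured", "known", "first", "only" and "open" are said of these compounds alone.

Three compounds have been measured in a physicochemical assay for solubility, measured as kinetic solubility, at pH 6.8; a lower number here means a less soluble compound, a higher number a more soluble compound:
compound 1 `Cc1cc(C(=O)Nc2cc(Oc3ccc4nc(NC(=O)C5CC5)nn4c3)ccc2C)n(C)n1`: 53 ug/mL
compound 2 `Cc1cc(NC(=O)c2cc(C)nn2C)cc(Oc2ccc3nc(NC(=O)C4CC4)nn3c2)c1`: 3.2 ug/mL
compound 3 `Cc1nc(C(=O)Nc2cc(Oc3ccc4nc(NC(=O)C5CC5)nn4c3)ccc2C)c(C)s1`: 0.16 ug/mL

Compound 3 gives the lowest number of the three; compound 2 sits above it and compound 1 highest, both gaps beyond the scatter. Compound 4 `Cc1ccc(Oc2ccc3nc(NC(=O)C4CC4)nn3c2)cc1NC(=O)c1ccnn1C` differs from compound 3 by 1-methyl-1H-pyrazol-5-yl in place of 2,5-dimethyl-1,3-thiazol-4-yl on a carbonyl carbon. Among the measured compounds shown here, the one step that bears on this is a 330-fold lower number from compound 1 to compound 3 (2.52 log units; beyond the scatter), where a 1,3-dimethyl-1H-pyrazol-5-yl amide on the same core gave the high number and the thiazole the low one. Compound 4 carries a 1-methyl-1H-pyrazol-5-yl instead, so a large rise is expected, roughly back toward compound 1: the estimated step is a 190-fold higher number from compound 3 to compound 4 (2.27 log units; beyond the scatter). Compound 4 is expected to give about 30 ug/mL, between 8 ug/mL and 100 ug/mL.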

Compound 4, solubility: > 80 ug/mL
Compound 4: a limit, no number (the forecaster's own chance of this, stated with the estimate: 5%); at least 2.6-fold (0.42 log units) between middle value and limit.
By their numbers in this assay, from the lowest: compound 3; then compound 2; then compound 1. At a limit, above all of these: compound 4.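

In this assay compound 4 gives > 80 ug/mL, which is a limit and not a number: the limit of > 80 ug/mL in this assay, at which 1 of the 4 values shown sits.

The pyrazole amide thus holds its large advantage over the thiazole without the methyl that compound 1 carries on its aromatic carbon, with an at least 500-fold higher number from compound 3 to compound 4 (2.69 log units; beyond the scatter). Hydrogen in place of that methyl gives an at least 1.5-fold higher number from compound 1 to compound 4 (0.17 log units; that floor lies within the scatter), a floor within the scatter, so no gain over compound 1 can be claimed.

As far as these compounds go, how far compound 4 truly lies from compound 1 remains open. So does how an amine or a carboxylic acid on the 1-methyl-1H-pyrazol-5-yl would read in this assay.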